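A Fluorocyclobutyl Amide on a Core That Lost Potency

A few compounds are considered here, and "the series" means these few. Any claim that something is new, unique, unknown or untested is made for them only; others in the source may bear on it.

Compound 1 `CN1CCc2nc(C#Cc3ccccc3)sc2C1` gives 34 nM in an assay on HEK293 cells for positive allosteric modulation of metabotropic glutamate receptor 5 (Homo sapiens), read by FLIPR, with a stated time of 1 h; on this read-out higher numbers stand for an effect only at larger amounts of compound and lower numbers for an effect already at smaller amounts. Compound 2 `CC(C)CN1CCc2nc(C#Cc3ccccc3)sc2C1` reaches only the limit of this assay , reading > 10000 nM. Compound 3 `O=C(C1CC1)N1CCc2nc(C#Cc3ccccc3)sc2C1` also reaches only the limit of this assay , with > 10000 nM. Compound 3 therefore stands among the weakest compounds measured: the step of an at least 290-fold higher number from compound 1 to compound 3 (2.46 log units; beyond the scatter) ends at the limit of > 10000 nM in this assay, at which 2 of the 3 values shown sit, as does the step of an at least 290-fold higher number from compound 1 to compound 2 (2.46 log units; beyond the scatter), while the step that the two limits leave unreadable from compound 2 to compound 3 cannot be read because both values are limits.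

Compound 4 `O=C(C1CC(F)C1)N1CCc2nc(C#Cc3ccccc3)sc2C1` differs from compound 3 by 3-fluorocyclobutyl in place of cyclopropyl on a carbonyl carbon. The amide carbonyl on the ring nitrogen, which compound 3 already carries, is kept; only the ring on the carbonyl carbon is changed. Among the compounds with values here, no measured step alters this acyl group, so the only guide is that both departures from the methyl of compound 1 ended at the limit. Compound 4 is therefore expected to remain at or near the limit, and the step that the limit leaves unreadable from compound 3 to compound 4 is expected to be unreadable or without any change beyond the scatter. The estimate for compound 4 in this assay is 15000 nM, with a range from 5000 nM to 50000 nM.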

Compound 4, half-maximal effective concentration: 85 nM
Estimate against measurement, compound 4: 180-fold (2.25 log units) above, and the stated range ends above it.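

With the carbonyl kept, 3-fluorocyclobutyl in place of cyclopropyl on a carbonyl carbon gives an at least 110-fold lower number from compound 3 to compound 4 (2.07 log units; beyond the scatter) in this assay, so an amide at this position does not by itself end the effect, as compound 3 alone had suggested. On the amine nitrogen in a ring, (3-fluorocyclobutyl)carbonyl in place of isobutyl gives an at least 110-fold lower number from compound 2 to compound 4 (2.07 log units; beyond the scatter), while the same group in place of methyl leaves a 2.5-fold higher number from compound 1 to compound 4 (0.40 log units; beyond the scatter), so a group larger than methyl can be carried here with only a modest loss, although compound 2 and compound 3 go against any general tolerance for larger groups. Compound 2 and compound 3 each stand at a limit, so the first two of these steps are bounds and not exact sizes: the limit of > 10000 nM in this assay, at which 2 of the 4 values shown sit.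

On these data alone, whether the recovered potency rests on the fluorine or on the four-membered ring stays open, and a plain cyclobutyl group on the same carbonyl carbon would separate the two. Also open, as far as these compounds go, is how a 3,3-difluorocyclobutyl or a 3-methoxycyclobutyl group would read in this assay.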